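This account rests on a few compounds, and the source may have more. Where it says the series, first, only, none or still open, it means among the compounds named here.

Measured in a physicochemical assay for solubility, using the shake flask method, in simulated intestinal fluid, measured as kinetic solubility, with a stated time of 2 h, at 25 degrees C, at pH 6.5; a higher number here means a more soluble compound, a lower number a less soluble compound:
Compound 1 `CCOC(=O)c1nc(C)c2c(c1N)C(=O)N(Cc1ccccc1)C2=O`: < 5000 nM
Compound 2 `Cc1noc(-c2nc(C)c3c(c2N)C(=O)N(Cc2ccc(F)cc2)C3=O)n1`: < 5000 nM

In this assay, compound 2 gives < 5000 nM, which is a limit of the assay and not a number. Compound 1 also gives only a limit, < 5000 nM. So neither compound has a number here, and both sit at the same limit: the limit of < 5000 nM in this assay, at which 2 of the 2 values shown sit.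

Compound 3 `Cc1noc(-c2nc(C)c3c(c2N)C(=O)N(Cc2cccc(C(F)(F)F)c2)C3=O)n1` carries 3-(trifluoromethyl)phenyl in place of 4-fluorophenyl on a saturated chain carbon bound to an amide-type nitrogen in a ring.

Among the compounds with values here, no measured step shows what such a change does in this assay, so no shift beyond the scatter is expected in either direction. The estimated change is a step that the limit leaves unreadable from compound 2 to compound 3, and another limit is the likeliest report. Compound 3 is estimated at 3000 nM. The expected range for compound 3 runs from 1000 nM to 6000 nM.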

Compound 3, solubility: < 5000 nM
Compound 3: no number, only a limit; the forecaster's own chance of this, stated with the estimate: 90%; the middle value is on the limit's open side.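

In this assay compound 3 gives < 5000 nM as a limit of the assay and not a number. Within the data shown here, no step from compound 2 to compound 3 can be read, because both values are limits: the limit of < 5000 nM in this assay, at which 3 of the 3 values shown sit. The compounds shown leave open how soluble each one actually is, and so what 3-(trifluoromethyl)phenyl in place of 4-fluorophenyl does to solubility.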